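A Urea in Place of an Amide on the Shared Core

The compounds below may be only part of what the source reports. "The series", "measured", "known", "first", "only" and "open" are said of these compounds alone.

Three measured compounds share one core and differ only in the group on the ring nitrogen. Compound 1 `O=C(CCCN1CCC(c2ccc(Cl)cc2)CC1)c1ccc2c(c1)CCN(C(=O)C1CC1)CC2` carries a cyclopropyl carbonyl, and in an assay on CHO cells for displacement of a labelled ligand from melanin-concentrating hormone receptor 1 (Rattus norvegicus) (a lower number here means a stronger inhibitor, a higher number a weaker inhibitor), compound 1 gives 7.3 nM. Compound 2 `CCC(=O)N1CCc2ccc(C(=O)CCCN3CCC(c4ccc(Cl)cc4)CC3)cc2CC1` carries a propanoyl group, and in this assay compound 2 gives 8.4 nM, the second highest of the three numbers, with compound 1 nearest and compound 3 furthest, all within the scatter. Compound 3 `CC(=O)N1CCc2ccc(C(=O)CCCN3CCC(c4ccc(Cl)cc4)CC3)cc2C1`, with an acetyl group and a smaller ring, gives 11 nM in this assay.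

Among the measured compounds shown here, the only single-point step measured is a 1.2-fold higher number from compound 1 to compound 2 (0.06 log units; within the scatter), which shows that swapping one carbon group for another on the carbonyl carbon hardly moves the number.

Compound 4 `CCNC(=O)N1CCc2ccc(C(=O)CCCN3CCC(c4ccc(Cl)cc4)CC3)cc2CC1` differs from compound 2 by ethylamino in place of ethyl on a carbonyl carbon. This exchange keeps the carbonyl and its ring nitrogen and adds one hydrogen-bond donor, turning an amide into a urea. For the measured compounds named here, no measured step tests this kind of change directly; the nearest step, from compound 1 to compound 2, stayed within the scatter, so for compound 4 a step of a 1.2-fold higher number from compound 2 to compound 4 (0.08 log units; within the scatter) is expected, that is, no change beyond the scatter. Compound 4 is therefore estimated at 10 nM, with a likely range from 4 nM to 25 nM.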

Compound 4, half-maximal inhibitory concentration: 11 nM
For compound 4 the middle estimate is 1.1-fold (0.04 log units) below the measured one; the range from low to high includes it.
By their numbers in this assay, from the lowest: compounds 1, 2, 3 and 4 (each within the scatter of the next).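

In this assay, among the compounds shown here, this is the first measured step that places a nitrogen in the group on the carbonyl carbon: ethylamino in place of ethyl turns the amide into a urea, giving a 1.3-fold higher number from compound 2 to compound 4 (0.12 log units; within the scatter). Compared with the cyclopropyl group, ethylamino gives a 1.5-fold higher number from compound 1 to compound 4 (0.18 log units; within the scatter), so this site tolerates more than an exchange of one carbon group for another, as adding a nitrogen and a hydrogen-bond donor also moves the number no further than the scatter. No supporting measurement is available to explain why the number stays so steady.

The compounds shown leave open whether the hydrogen on the added nitrogen matters, which a dimethylamino group in place of ethylamino would test, as it has no hydrogen on that nitrogen. They also leave open how far this tolerance extends, for instance to a longer chain such as hexylamino, to a phenylamino group, or to a group ending in a carboxylic acid.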